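The source may report more compounds than this note shows. Statements on the series, on what has been measured and on what is new or still open speak of the compounds shown alone.

Of the compounds shown here, two share a common core and have been tested in a functional assay, read by spectrophotometry, with a stated time of 30 min; on this read-out lower numbers stand for stronger inhibition and higher numbers for weaker inhibition. Compound 1, `N[C@@H](CCC(=O)NNc1ccccc1F)C(=O)O`, gives 10.9 ug/mL in this assay. Compound 2, `Cc1cccc(NNC(=O)CC[C@H](N)C(=O)O)c1`, gives 10.1 ug/mL. Of these two numbers, compound 2 holds the lower one, but the gap to compound 1 lies within the usual scatter of such measurements, so the two cannot be told apart on these data.

The next step leads from compound 2 to compound 3, `N[C@@H](CCC(=O)NNc1cccc(F)c1)C(=O)O`. The change is fluoro in place of methyl on an aromatic carbon. For the measured compounds named here, with only two measured compounds and no single-point step between them, there is no measured guide for this exchange; the expectation is therefore a step no larger than the scatter, in no particular direction. For compound 3 the expected value in this assay is 10.5 ug/mL, with a likely range from 6 ug/mL to 18 ug/mL, which means an expected step of a 1.0-fold higher number from compound 2 to compound 3 (0.02 log units; within the scatter).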

Compound 3, half-maximal inhibitory concentration: 11.4 ug/mL
Compound 3: middle estimate off by 1.1-fold (0.04 log units), on the low side; the range from low to high includes it.
By their numbers in this assay, from the lowest: compounds 2, 1 and 3 (each within the scatter of the next).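

On this aromatic carbon, meta to a large group, fluoro in place of methyl gives a 1.1-fold higher number from compound 2 to compound 3 (0.05 log units; within the scatter) in this assay and the two compounds cannot be told apart. For the compounds shown here, this is the only comparison here between compounds that differ in one place, and it shows that the read-out stays within the scatter when either of these two groups sits at this position. No measurement at hand bears on why the two groups read alike.

Methyl and fluoro each bring a single heavy atom, so the compounds shown leave open whether a larger group on this carbon, such as methoxy or trifluoromethyl, would read the same. Also open, as far as these compounds go, is how an amine or a hydroxyl group would read at this position.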